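Replacing iodo with 3-methoxyphenyl: what to expect

A few compounds are considered here, and "the series" means these few. Any claim that something is new, unique, unknown or untested is made for them only; others in the source may bear on it.

For the measured compounds named here, in a functional assay on AGS cells (Homo sapiens) for inhibition, read by reporter gene assay (a higher number here means a weaker inhibitor, a lower number a stronger inhibitor), compound 3 (`O=C(COc1ccc(I)cc1)Nc1cccc(C(=O)O)c1`) gives 3500 nM, the lowest number so far. Compound 2 (`O=C(COc1ccc(Cl)cc1)Nc1cccc(C(=O)O)c1`) gives 10000 nM. Compound 1 (`CC(=O)c1ccc(OCC(=O)Nc2cccc(C(=O)O)c2)cc1`) gives > 30000 nM, which is a limit of the assay. Compound 4 (`COc1cccc(-c2ccc(OCC(=O)Nc3cccc(C(=O)O)c3)cc2)c1`) has 3-methoxyphenyl in place of iodo on an aromatic carbon. Two measured swaps at that same place bear on this change: a 2.9-fold lower number from compound 2 to compound 3 (0.46 log units; beyond the scatter), and an at least 8.5-fold lower number from compound 1 to compound 3 (0.93 log units; beyond the scatter). Neither swap brings in a ring, so they are only a loose guide. A modest further fall in this assay is still expected, an estimated 2.3-fold lower number from compound 3 to compound 4 (0.37 log units; beyond the scatter). For compound 4 the estimated value is 1500 nM, with an expected range of 300 nM to 8000 nM.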

Compound 4, half-maximal inhibitory concentration: 35000 nM
Compound 4: middle estimate off by 23-fold (1.37 log units), on the low side; the measured number lies above the stated range.
By their numbers in this assay, from the lowest: compound 3; then compound 2; then compound 4.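

Until now, each swap at this aromatic carbon had lowered the number, but bringing in a ring reverses that direction: in this assay there is a 10-fold higher number from compound 3 to compound 4 (1.00 log units; beyond the scatter), and also a 3.5-fold higher number from compound 2 to compound 4 (0.54 log units; beyond the scatter). The gain from chloro to iodo therefore does not carry over to 3-methoxyphenyl, and compound 4 ends up with a higher number than either halogen compound. The step from compound 1 to compound 4 cannot be read: the limit of > 30000 nM in this assay, at which 1 of the 4 values shown sits.

Going by these compounds, whether the rise comes from the ring itself or from its methoxy group stays open. A plain phenyl group at this place would separate the two.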